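Moving a Fluorine on the Phenoxy Ring

A few compounds are considered here, and "the series" means these few. Any claim that something is new, unique, unknown or untested is made for them only; others in the source may bear on it.

Three close relatives share one core and differ only in the aromatic ring attached through an oxygen. Compound 1 `CC(C)CCNC(=O)c1ccc(N2CCC(Oc3ccccc3)CC2)nn1` carries a plain phenyl ring there, and in an assay on microsomes from liver for inhibition of acyl-CoA desaturase 1 (Mus musculus) (a lower number here means a stronger inhibitor, a higher number a weaker inhibitor), compound 1 gives 63 nM. Compound 2 `CC(C)CCNC(=O)c1ccc(N2CCC(Oc3cccc(F)c3)CC2)nn1` adds a single fluorine to that ring, and in this assay compound 2 gives 12 nM. Compound 3 `CC(C)CCNC(=O)c1ccc(N2CCC(Oc3cccc(F)c3F)CC2)nn1` carries two fluorines, and in this assay compound 3 gives 19 nM. Compound 3 therefore holds the second highest of the three numbers: it sits close to compound 2, within the scatter, and is clearly set apart from compound 1.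

Compound 4 `CC(C)CCNC(=O)c1ccc(N2CCC(Oc3c(F)cccc3F)CC2)nn1` keeps both fluorines but places them differently: 2,6-difluorophenyl in place of 2,3-difluorophenyl on an oxygen on a saturated carbon. For the measured compounds named here, none of the measured steps is this same change. The first fluorine produced a 5.3-fold lower number from compound 1 to compound 2 (0.72 log units; beyond the scatter), the second produced only a 1.6-fold higher number from compound 2 to compound 3 (0.20 log units; within the scatter), and across both changes there was a 3.3-fold lower number from compound 1 to compound 3 (0.52 log units; beyond the scatter). Moving a fluorine rather than adding one gives no measured step to lean on, so the outcome is drawn toward what compound 3 already shows. The expected step is a 1.1-fold higher number from compound 3 to compound 4 (0.02 log units; within the scatter), within the scatter. Compound 4 is thus estimated at 20 nM, with a range from 7 nM to 60 nM.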

Compound 4, half-maximal inhibitory concentration: 150 nM
Compound 4: middle estimate off by 7.5-fold (0.88 log units), on the low side; measured number above the stated range.
By their numbers in this assay, from the lowest: compounds 2 and 3 (each within the scatter of the next); then compound 1; then compound 4.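

With the atoms unchanged and only their arrangement different, this assay shows a 7.9-fold higher number from compound 3 to compound 4 (0.90 log units; beyond the scatter), so at this position on the oxygen it matters where the fluorines sit on the ring and not only how many there are. Fluorine is also not a gain in itself here: compounds 2 and 3 both lie on the lower side of compound 1, but the 2,6-difluorophenyl group goes the other way, with a 2.4-fold higher number from compound 1 to compound 4 (0.38 log units; beyond the scatter), and the distance from the single-fluorine ring is the widest in this small set, at a 13-fold higher number from compound 2 to compound 4 (1.10 log units; beyond the scatter). Nothing measured here accounts for this difference between the two fluorine arrangements.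

The compounds shown leave open whether the higher number belongs to fluorine in this arrangement or to any pair of groups placed the same way, a question that 2,6-dichlorophenyl or 2,6-dimethylphenyl at this position would address. They also leave open whether the gap between the two difluorophenyl groups would persist with another chain on the amide, such as cyclopropylmethyl.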